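The compounds below may be only part of what the source reports. "The series", "measured", "known", "first", "only" and "open" are said of these compounds alone.

Working notes on the series. In a toxicity assay on MDCK cells (Canis lupus familiaris) for cytotoxicity, read by crystal violet staining, with a stated time of 48 h (a lower number here means that less compound is tolerated, a higher number that more compound is tolerated), compound 1 `Cc1ccc2[nH]c(=O)c(CN(Cc3ccccc3)Cc3ccc(C(C)(C)C)cc3)cc2c1` returns only a limit, > 5000 nM. Compound 2 `Cc1ccc2[nH]c(=O)c(CN(Cc3ccc(OCC(=O)O)cc3)Cc3ccc(C(C)(C)C)cc3)cc2c1` likewise returns only a limit in this assay, > 10000 nM. Compound 3 `COc1ccc(CN(Cc2ccc(C(C)(C)C)cc2)Cc2cc3cc(C)ccc3[nH]c2=O)cc1` also stands at a limit in this assay, > 10000 nM. Compound 3 therefore sits at the limit of > 10000 nM in this assay, at which 2 of the 3 values shown sit. The remaining value of the three sits at the limit of > 5000 nM in this assay, at which 1 of the 3 values shown sits.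

Among the measured compounds shown here, none of the measured steps can be sized. The step that the two limits leave unreadable from compound 1 to compound 3 and the step that the two limits leave unreadable from compound 2 to compound 3 both run between two limits, and the same holds for a step that the two limits leave unreadable from compound 1 to compound 2. Nothing among the three measured compounds shows a change in this assay that is readable at all.

Compound 4 `Cc1ccc2[nH]c(=O)c(CN(Cc3ccc(C(N)=O)cc3)Cc3ccc(C(C)(C)C)cc3)cc2c1` differs from compound 3 by carbamoyl in place of methoxy on an aromatic carbon. For the measured compounds named here, the steps that bear on this change all carry no readable size, so no step beyond the scatter is expected in this assay, and compound 4 is expected once more to be tolerated up to the top of the tested range. The estimate for compound 4 is 15000 nM, with a range from 8000 nM to 40000 nM. The step this estimate implies, a step that the limit leaves unreadable from compound 3 to compound 4, is expected to lie within the scatter, most likely as a further limit rather than a number.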

Compound 4, half-maximal cytotoxic concentration: > 5000 nM
Compound 4 was reported as a limit; the forecaster's own chance of this, stated with the estimate: 80%; the middle value is on the limit's open side.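

In this assay compound 4 also returns only a limit: the limit of > 5000 nM in this assay, at which 2 of the 4 values shown sit. Among the compounds shown here, with all four values at limits, no step to compound 4 from compound 1, compound 2 or compound 3 can be read. The compounds shown leave open whether any of these aromatic substituents changes the half-maximal cytotoxic concentration, which no value here gives as a number.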